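The source may hold more compounds than are shown below. What is called first, only, known or untested is meant among the compounds shown, and "the series" means these compounds.

Measured compounds in a functional assay on MDA-MB-231 cells (Homo sapiens) for cytotoxicity, read by MTT assay, with a stated time of 48 h; a higher number here means a weaker inhibitor, a lower number a stronger inhibitor:

Compound 1, `COc1ccc(-c2nc(C(=O)/C=C\Nc3ccc4[nH]ccc4c3)c3ccccn23)cc1`: compound 1 gives 28700 nM.
Compound 2, `COc1ccc(-c2nc(C(=O)/C=C\Nc3ccc(Cl)cc3)c3ccccn23)cc1`: compound 2 reaches only the limit of this assay, > 30000 nM, not a number.
Compound 3, `O=C(/C=C\Nc1ccc2[nH]ccc2c1)c1nc(-c2ccc(C(F)(F)F)cc2)n2ccccc12`: compound 3 gives 1180 nM.

The unmeasured compound 4 is `O=C(/C=C\Nc1ccc(Cl)cc1)c1nc(-c2ccc(C(F)(F)F)cc2)n2ccccc12`. Its core is that of compound 3, which differs from the core of compound 1 by trifluoromethyl in place of methoxy on an aromatic carbon; that change made a 24-fold lower number from compound 1 to compound 3 (1.39 log units; beyond the scatter).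

The change from compound 3 to compound 4 is 4-chlorophenyl in place of 1H-indol-5-yl on an amine nitrogen. The same change has already been made once, from compound 1 to compound 2, as 4-chlorophenyl in place of 1H-indol-5-yl on an amine nitrogen, where it gave an at least 1.0-fold higher number from compound 1 to compound 2 (0.01 log units; that floor lies within the scatter). The size of that step is hidden by the limit of > 30000 nM in this assay, at which 1 of the 3 values shown sits, so only its direction, toward a higher number, is shown.

On the core of compound 3 the same change is expected to give a 3.8-fold higher number from compound 3 to compound 4 (0.58 log units; beyond the scatter), resting on the direction of the step from compound 1 to compound 2 and on the value of compound 3, 1180 nM. Compound 4 is therefore estimated at 4500 nM, with a range from 1500 nM to 15000 nM.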

Compound 4, half-maximal inhibitory concentration: 3840 nM
Beside the measured number, compound 4's estimate is 1.2-fold (0.07 log units) above it; measured number inside the range.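

In this assay the change to 4-chlorophenyl in place of 1H-indol-5-yl on the amine nitrogen gives a 3.3-fold higher number from compound 3 to compound 4 (0.51 log units; beyond the scatter) and so can be sized on the core of compound 3, where it runs in the same direction as on the core of compound 1: the same change on two cores in this assay, an at least 1.0-fold higher number (0.01 log units; that floor lies within the scatter) from compound 1 to compound 2 and a 3.3-fold higher number (0.51 log units; beyond the scatter) from compound 3 to compound 4; the limit leaves it open whether they differ. Trifluoromethyl in place of methoxy also runs the same way on both cores, now with an at least 7.8-fold lower number from compound 2 to compound 4 (0.89 log units; beyond the scatter) set beside the earlier step: the same change on two cores in this assay, a 24-fold lower number (1.39 log units; beyond the scatter) from compound 1 to compound 3 and an at least 7.8-fold lower number (0.89 log units; beyond the scatter) from compound 2 to compound 4; the limit leaves it open whether they differ. Each change thus keeps its direction across these two cores, but whether it keeps its size is not shown, and the value of compound 2 is a limit and not a number: the limit of > 30000 nM in this assay, at which 1 of the 4 values shown sits.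

The compounds shown leave open whether the direction would hold for other groups on the amine nitrogen, such as a plain phenyl or a pyridyl. They also leave open how the indolyl and 4-chlorophenyl compounds would compare with a nitrile or a chlorine in place of trifluoromethyl.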